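Swapping the nitrogen methyl of compound 2 for hydrogen

This account rests on a few compounds, and the source may have more. Where it says the series, first, only, none or still open, it means among the compounds named here.

Compound 2 (`Cn1c(/C=C/C(=O)c2ccccc2)cc(Br)c1Br`) gives >= 100000 nM in a functional assay on WRL68 cells (Homo sapiens) for cytotoxicity, read by MTT assay, with stated times of 6 h and 48 h (a lower number here means a stronger inhibitor, a higher number a weaker inhibitor), and this is a limit of the assay, not a number (the limit of >= 100000 nM in this assay, at which 1 of the 3 values shown sits). Its two relatives carry a hydroxy group on the aromatic ring that compound 2 lacks. Compound 1 (`Cn1c(/C=C/C(=O)c2ccccc2O)cc(Br)c1Br`) gives 330 nM in this assay, and compound 3 (`Cn1c(/C=C/C(=O)c2ccc(O)cc2)cc(Br)c1Br`) gives 1910 nM in the same test.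

Compound 4 (`O=C(/C=C/c1cc(Br)c(Br)[nH]1)c1ccccc1`) has no such hydroxy group and departs from compound 2 in a single place (hydrogen in place of methyl on an aromatic nitrogen), with hydrogen in place of methyl on an aromatic nitrogen. Two measured steps start or end at compound 2: one is large (an at least 300-fold higher number from compound 1 to compound 2 (2.48 log units; beyond the scatter)), and the other is also large (an at least 52-fold lower number from compound 2 to compound 3 (1.71 log units; beyond the scatter)). Both concern a hydroxy group on an aromatic carbon, and neither touches the nitrogen, so they offer no direct size for this change. They show only that one small edit can move compound 2 far in this series. Only a move toward a lower number could show up as a measured step, and a modest one is expected (an at least 2.5-fold lower number from compound 2 to compound 4 (0.39 log units; beyond the scatter)). The estimate for compound 4 is 40000 nM in this assay, with an expected range from 10000 nM to 100000 nM and a real chance of another limit.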

Compound 4, half-maximal inhibitory concentration: >= 100000 nM
Compound 4: only a limit was reported; the forecaster's own chance of this, stated with the estimate: 45%; middle value at least 2.5-fold (0.39 log units) away from the limit.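

Compound 2 and compound 4 both sit at a limit of this assay, not at a number, so the step between them cannot be read: the limit of >= 100000 nM in this assay, at which 2 of the 4 values shown sit. The compounds shown leave open whether hydrogen in place of methyl on an aromatic nitrogen would change the result in a compound that carries a hydroxy group, such as compound 1 or compound 3.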